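A Ring Swap and Its Expected Effect on Cell Toxicity

The source may hold more compounds than are shown below. What is called first, only, known or untested is meant among the compounds shown, and "the series" means these compounds.

Among the measured compounds shown here, compound 1 `Cc1nc2ccccc2cc1-c1nnc(-c2cccs2)o1` is one of two compounds tested in an ADME assay on A549 cells (Homo sapiens) for cytotoxicity, read by MTT assay, with a stated time of 48 h (a lower number here means a stronger inhibitor, a higher number a weaker inhibitor), and in this assay compound 1 gives 99.4 ug/mL, the only plain number in the set. Compound 2 `CC(=O)N1N=C(c2cc3ccccc3nc2C)CC1c1ccc([N+](=O)[O-])cc1` reaches only a limit of the assay, > 200 ug/mL; that is the limit of > 200 ug/mL in this assay, at which 1 of the 2 values shown sits. Compound 3 `Cc1nc2ccccc2cc1-c1nnc(-c2cccnc2)o1` differs from compound 1 by pyridin-3-yl in place of thiophen-2-yl on an aromatic carbon. For the measured compounds named here, no measured pair shows what such a swap does, so no shift beyond the usual scatter is expected, and the estimated step is a 1.1-fold higher number from compound 1 to compound 3 (0.04 log units; within the scatter). Compound 3 is therefore expected to give about 110 ug/mL, with a likely range from 50 ug/mL to 200 ug/mL.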

Compound 3, half-maximal inhibitory concentration: 139 ug/mL
Compound 3: middle estimate off by 1.3-fold (0.10 log units), on the low side, within the range that was stated.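

Measured in this assay, putting pyridin-3-yl in place of thiophen-2-yl on this aromatic carbon gives a 1.4-fold higher number from compound 1 to compound 3 (0.15 log units; within the scatter). This position therefore accepts a six-membered aromatic ring with a ring nitrogen in place of a five-membered aromatic ring with sulfur, with no shift that stands out from the scatter. Nothing shown gives a cause for this small step. On these data alone, whether a group of another kind here, such as an amine or a carboxylic acid, would move the number beyond the scatter stays open.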